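A Methyl Ether Opened on a Chlorophenyl Substituent

A few compounds are considered here, and "the series" means these few. Any claim that something is new, unique, unknown or untested is made for them only; others in the source may bear on it.

Measured compounds:
compound 1 `O=C(Nc1cccc(-n2cc(-c3ccncc3)c(-c3ccc(Cl)c(O)c3)n2)c1)Nc1cccc(C(F)(F)F)c1` gives > 32500 nM
compound 2 `COc1cc(-c2nn(-c3cccc(NC(=O)Nc4ccc(Cl)c(Cl)c4)c3)cc2-c2ccncc2)ccc1Cl` gives > 50000 nM

The two measured compounds share a core and differ in the group on the aromatic oxygen and in the aryl part of the urea. In a functional assay on SNB-75 cells (Homo sapiens) for inhibition, read by sulforhodamine B assay, with a stated time of 48 h (a higher number here means that more compound is tolerated, a lower number that less compound is tolerated), compound 1 gives > 32500 nM, which is a limit of the assay rather than a number. Compound 2 gives > 50000 nM in this assay, again a limit and not a number. So compound 2 stands only at a limit, with nothing to rank it against: one value sits at the limit of > 32500 nM in this assay, at which 1 of the 2 values shown sits, and the other at the limit of > 50000 nM in this assay, at which 1 of the 2 values shown sits.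

Compound 3 `O=C(Nc1cccc(-n2cc(-c3ccncc3)c(-c3ccc(Cl)c(O)c3)n2)c1)Nc1ccc(Cl)c(Cl)c1` is compound 2 with hydrogen in place of methyl on an oxygen on an aromatic ring. Going by the values given here, no measured pair shows this change on its own. With both measured values at a limit, the step in this assay from compound 2 to compound 3 is expected to be none beyond the scatter, and compound 3 is expected to sit at a limit as well. The expected step of a number no higher from compound 2 to compound 3 (the limit leaves the size open) is therefore flat. Compound 3 is estimated at 50000 nM, within 20000 nM to 120000 nM.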

Compound 3, concentration lethal to 50% of the cells: > 32500 nM
Compound 3 ended at the assay's limit (the forecaster's own chance of this, stated with the estimate: 80%); the middle value is on the limit's open side.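

In this assay compound 3 gives > 32500 nM, which is a limit of the assay and not a number. No step can be read from this result, either from compound 2 to compound 3 or from compound 1 to compound 3. The compounds shown leave open whether methoxy to hydroxy, or the change of aryl group on the urea, shifts the value in this assay at all.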